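Amide substituent series: carboxyethyl in place of protected aminoethyl

The source may hold more compounds than are shown below. What is called first, only, known or untested is meant among the compounds shown, and "the series" means these compounds.

Three amides of the shared core have been measured in a functional assay on MCF7 cells (Homo sapiens) for antiproliferative activity, read by MTT assay, with a stated time of 24 h; on this read-out lower numbers stand for stronger inhibition and higher numbers for weaker inhibition. Compound 1 `CCn1c(C(=O)NCC(=O)OC)ccc1C(CC)(CC)c1ccc(OCS(=O)(=O)c2ccccc2)c(C)c1` sits at the assay limit, giving > 50000 nM in this assay. Compound 2 `CCn1c(C(=O)NCCNC(=O)OC(C)(C)C)ccc1C(CC)(CC)c1ccc(OCS(=O)(=O)c2ccccc2)c(C)c1` likewise returns only the limit > 50000 nM. Among the compounds with values here, compound 3 `CCn1c(C(=O)N[C@@H](CO)CCCO)ccc1C(CC)(CC)c1ccc(OCS(=O)(=O)c2ccccc2)c(C)c1` is the one compound with a number, 29600 nM. The steps of an at least 1.6-fold lower number from compound 1 to compound 3 (0.22 log units; that floor lies within the scatter) and an at least 1.6-fold lower number from compound 2 to compound 3 (0.22 log units; that floor lies within the scatter) therefore carry only a floor, and the step that the two limits leave unreadable from compound 1 to compound 2 cannot be read at all, since the limit of > 50000 nM in this assay, at which 2 of the 3 values shown sit, covers both ends of it.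

Compound 4 `CCn1c(C(=O)N[C@@H](C)C(=O)O)ccc1C(CC)(CC)c1ccc(OCS(=O)(=O)c2ccccc2)c(C)c1` arises from compound 2 through (1-carboxyethyl in place of 2-((tert-butoxycarbonyl)amino)ethyl on an amide-type nitrogen). Within the data shown here, no measured step crosses from a 2-((tert-butoxycarbonyl)amino)ethyl group to a 1-carboxyethyl group, and the readable comparisons in this assay give floors only. Of the measured compounds, the nearest to compound 4 in the size of the group on the amide-type nitrogen is compound 1, which gives > 50000 nM in this assay. The expected step for compound 4 is therefore a step that the limit leaves unreadable from compound 2 to compound 4, no step beyond the scatter. The estimated value for compound 4 is 60000 nM, ranging from 20000 nM to 150000 nM, and is expected most likely to come back again as a limit rather than a number.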

Compound 4, half-maximal inhibitory concentration: 35500 nM
Beside the measured number, compound 4's estimate is 1.7-fold (0.23 log units) above it; the measured number falls inside the stated range.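

In this assay, 1-carboxyethyl on the amide-type nitrogen gives the series a second number, and the comparison of the two numbers is a 1.2-fold higher number from compound 3 to compound 4 (0.08 log units; within the scatter), so these two groups are not separated at this position. Against the two remaining amides, the change gives only an at least 1.4-fold lower number from compound 2 to compound 4 (0.14 log units; that floor lies within the scatter) and an at least 1.4-fold lower number from compound 1 to compound 4 (0.14 log units; that floor lies within the scatter), so neither comparison shows a gain beyond the scatter. Compound 1 and compound 2 supply floors and no sizes because of the assay limit: the limit of > 50000 nM in this assay, at which 2 of the 4 values shown sit.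

On these data alone, whether a free 2-aminoethyl group or a longer carboxyalkyl chain on the amide-type nitrogen would move the number beyond the scatter from compound 3 and compound 4 stays open. Also open, as far as these compounds go, is how the opposite stereocentre of the 1-carboxyethyl group would read.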